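This account rests on a few compounds, and the source may have more. Where it says the series, first, only, none or still open, it means among the compounds named here.

Three compounds have been measured:
compound 1, `c1ccc(-c2nnc(-c3c[nH]c4ccccc34)o2)cc1`;
compound 2, `c1ccc2c(-c3nnc(-c4ccncc4)o3)c[nH]c2c1`;
compound 3, `c1cncc(-c2nnc(-c3c[nH]c4ccccc34)o2)c1`.

In a functional assay on PC-3 cells (Homo sapiens) for cytotoxicity, read by MTT assay (a lower number here means a stronger inhibitor, a higher number a weaker inhibitor), compound 2 gives 4100 nM. Compound 3 gives 711000 nM in this assay. Compound 1 reaches only a limit of the assay, > 1000000 nM, and no number. Compound 3 thus stands at the highest of the two numbers; its nearest neighbour is compound 2, and the step of a 170-fold higher number from compound 2 to compound 3 (2.24 log units; beyond the scatter). Relative to compound 1, the step of an at least 1.4-fold lower number from compound 1 to compound 3 (0.14 log units; that floor lies within the scatter), so these two sit close together near the weak end.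

Compound 4, `Clc1ccc(-c2nnc(-c3c[nH]c4ccccc34)o2)cc1`, is the next compound. Its change from compound 3 is this: 4-chlorophenyl in place of pyridin-3-yl on an aromatic carbon. Among the compounds with values here, of the measured steps, only the one from compound 1 to compound 3 involves the same position and the same kind of swap between a carbon-only ring and pyridin-3-yl, and it was small: an at least 1.4-fold lower number from compound 1 to compound 3 (0.14 log units; that floor lies within the scatter). Going the other way, now with a chlorine on the carbon-only ring, is therefore expected to change the number little, if anything upward, and the expected step is a 1.3-fold higher number from compound 3 to compound 4 (0.10 log units; within the scatter). For compound 4 the estimate in this assay is 900000 nM, between 200000 nM and 4000000 nM, with a real chance that only a limit is reported.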

Compound 4, half-maximal inhibitory concentration: 41600 nM
Compound 4: the middle estimate sits 22-fold (1.34 log units) above what was measured; the measured number lies below the stated range.
By their numbers in this assay, from the lowest: compound 2; then compound 4; then compound 3. At a limit, above all of these: compound 1.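

In this assay, within the data shown here, the earlier compounds suggested that only pyridin-4-yl on this carbon of the five-membered ring gave a clearly lower number, yet a ring of carbon only can also do so once it carries a chlorine. Chloro in place of hydrogen on the phenyl group is a single small change with a large result (an at least 24-fold lower number from compound 1 to compound 4 (1.38 log units; beyond the scatter)), although compound 1 stands at a limit of the assay, so this step gives only a floor: (the limit of > 1000000 nM in this assay, at which 1 of the 4 values shown sits). The 4-chlorophenyl group also beats pyridin-3-yl (a 17-fold lower number from compound 3 to compound 4 (1.23 log units; beyond the scatter)) but does not match pyridin-4-yl (a 10-fold higher number from compound 2 to compound 4 (1.01 log units; beyond the scatter)), so the ring nitrogen alone does not decide the outcome at this position, and pyridin-4-yl still gives the lowest number of the set.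

Going by these compounds, what remains open is whether this gain is specific to chlorine, or whether a methyl, a methoxy group, an amine or a carboxylic acid in the same place on the phenyl ring would lower the number as well. The compounds shown also cannot tell whether a chlorine added to the pyridin-4-yl ring of compound 2 would lower its number further.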